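Phenyl for Methyl at the Amine Chain of Compound 3

A few compounds are considered here, and "the series" means these few. Any claim that something is new, unique, unknown or untested is made for them only; others in the source may bear on it.

In a functional assay on HT-29 cells (Homo sapiens) for cytotoxicity, read by MTT assay, with a stated time of 24 h, tested at 32 ug/mL (a higher number here means a stronger effect of the compound at the concentration tested, a lower number a weaker effect), compound 3 `CCN1CCN(CC(=O)Nc2ccc(-c3nc(-c4ccccc4)c(-c4ccccc4)n3C)cc2)CC1` gives 38.8%, the lowest of the three measured compounds. Compound 1 `Cn1c(-c2ccc(NC(=O)CSc3nc4cc(Cl)ccc4o3)cc2)nc(-c2ccccc2)c1-c1ccccc1` gives 61.9% and compound 2 `Cn1cnnc1SCC(=O)Nc1ccc(-c2nc(-c3ccccc3)c(-c3ccccc3)n2C)cc1` gives 86.1%. The steps of a number 23.1 percentage points lower from compound 1 to compound 3 (beyond the scatter) and a number 47.3 percentage points lower from compound 2 to compound 3 (beyond the scatter) both swap the group on the saturated chain carbon bound to the carbonyl carbon, as does a number 24.2 percentage points higher from compound 1 to compound 2 (beyond the scatter). Compound 4 `Cn1c(-c2ccc(NC(=O)CN3CCN(Cc4ccccc4)CC3)cc2)nc(-c2ccccc2)c1-c1ccccc1` alters a different place: phenyl in place of methyl on a saturated chain carbon bound to an amine nitrogen in a ring, the same difference read one bond further out being ethyl to benzyl. Going by the values given here, no measured step touches this place, so there is no basis for a large change in either direction. Compound 4 is therefore expected to give 45%, between 25% and 70%, a step of a number 6.2 percentage points higher from compound 3 to compound 4 (within the scatter) that is estimated rather than measured.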

Compound 4, a percentage reported as activity, at one concentration (the size of the read-out at that concentration, not a potency): 40%
Estimate against measurement, compound 4: 5 percentage points above, within the range that was stated.
By their numbers in this assay, from the lowest: compounds 3 and 4 (each within the scatter of the next); then compound 1; then compound 2.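

In this assay, phenyl in place of methyl on a saturated chain carbon bound to an amine nitrogen in a ring gives a number 1.2 percentage points higher from compound 3 to compound 4 (within the scatter), so the added aromatic ring leaves the read-out within the scatter. The earlier steps shown here all swapped the whole group on the carbon bound to the carbonyl carbon, whereas this one shows that the outer end of the amine group can be enlarged with no step beyond the scatter. Nothing measured here gives a reason for this result. Going by these compounds, whether a carboxylic acid or an amine on that end, or a longer chain, would give a larger step remains open.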